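The compounds below may be only part of what the source reports. "The series", "measured", "known", "first", "only" and "open" are said of these compounds alone.

Notes on the series in an ADME assay on Vero cells (Chlorocebus sabaeus) for cytotoxicity, read by MTT assay, with a stated time of 72 h; a higher number here means that more compound is tolerated, a lower number that less compound is tolerated. Compound 1 `COC(=O)c1cc(-c2cccc(NC(=O)c3ccc(OCc4ccc(Cl)cc4)cc3)c2)on1` gives in this assay only a limit, > 80 ug/mL; the limit of > 80 ug/mL in this assay, at which 1 of the 3 values shown sits, marks where compound 1 stands. Compound 2 `COC(=O)c1cc(-c2cccc(NC(=O)c3ccc(/C=C/C(=O)c4cc(F)ccc4F)cc3)c2)on1` gives in this assay only a limit, > 40 ug/mL. Compound 3 `COC(=O)c1cc(-c2cccc(NC(=O)c3ccc(/C=C/C(=O)c4ccccc4C)cc3)c2)on1` gives in this assay only a limit, > 25 ug/mL. The steps among these three stay unreadable: a step that the two limits leave unreadable from compound 1 to compound 2, a step that the two limits leave unreadable from compound 1 to compound 3 and a step that the two limits leave unreadable from compound 2 to compound 3. Compound 4 `COC(=O)c1cc(-c2cccc(NC(=O)c3ccc(/C=C/C(=O)c4ccccc4Cl)cc3)c2)on1` is not yet measured in this assay; it differs from compound 1 by 2-((2-chlorophenyl)carbonyl)ethenyl in place of (4-chlorobenzyl)oxy on an aromatic carbon. The two unreadable steps from compound 1 to compound 2 and to compound 3 bear on this change, so no step in either direction beyond the scatter can be expected. Compound 4 is expected at 50 ug/mL, between 20 ug/mL and 120 ug/mL, most likely again only as a limit. The expected step is an at least 1.6-fold lower number from compound 1 to compound 4 (0.20 log units; that floor lies within the scatter).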

Compound 4, half-maximal cytotoxic concentration: > 25 ug/mL
Compound 4: only a limit was reported; the forecaster's own chance of this, stated with the estimate: 70%; the middle value does not contradict the limit.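

In this assay compound 4 gives only a limit, > 25 ug/mL. Its steps from compound 1, compound 2 and compound 3 cannot be read. The compounds shown leave open at what concentration any of these four reaches half-maximal cytotoxicity.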